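This account rests on a few compounds, and the source may have more. Where it says the series, first, only, none or still open, it means among the compounds named here.

Measured so far:
- compound 1 `Cc1ccc(-c2nn(-c3ccccc3)cc2-c2nc3ccccc3n2S(=O)(=O)c2ccc(F)cc2)cc1`: 167000 nM
- compound 2 `Cc1ccc(-c2nn(-c3ccccc3)cc2-c2nc3ccccc3n2S(=O)(=O)c2ccc(C(F)(F)F)cc2)cc1`: 89300 nM

In an ADME assay on cells (Hepatocyte, Mus musculus) for cytotoxicity, read by MTT assay, with a stated time of 24 h (a lower number here means that less compound is tolerated, a higher number that more compound is tolerated), compound 1 gives 167000 nM and compound 2 gives 89300 nM. Among the measured compounds shown here, these are the only two numbers available, and they lie within the usual scatter of each other, so compound 1 cannot be separated from its one neighbour.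

Compound 3 `O=S(=O)(c1ccc(F)cc1)n1c(-c2cn(-c3ccccc3)nc2-c2ccc(C(F)(F)F)cc2)nc2ccccc21` differs from compound 1 in one place: trifluoromethyl in place of methyl on an aromatic carbon. In words, this is trifluoromethyl in place of methyl on an aromatic carbon, para to a large group, or 4-methylphenyl turning into 4-(trifluoromethyl)phenyl.

For the measured compounds named here, no measured step makes this exact change. The closest evidence is a 1.9-fold lower number from compound 1 to compound 2 (0.27 log units; within the scatter), where trifluoromethyl also enters, but in place of fluoro and at a different place in the molecule. That single step offers only a weak guide, and since it stayed small, no step beyond the scatter is expected here. The expected change is a 1.5-fold lower number from compound 1 to compound 3 (0.18 log units; within the scatter). For compound 3 the estimated value is 110000 nM, with an expected range of 50000 nM to 230000 nM.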

Compound 3, half-maximal cytotoxic concentration: 83300 nM
Estimate against measurement, compound 3: 1.3-fold (0.12 log units) above; the measured number falls inside the stated range.
By their numbers in this assay, from the lowest: compounds 3, 2 and 1 (each within the scatter of the next).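

In this assay the change from methyl to trifluoromethyl, on an aromatic carbon para to a large group, gives a 2.0-fold lower number from compound 1 to compound 3 (0.30 log units; within the scatter) and so stays inside the normal noise of the measurement. Among the compounds shown here, this is the first reading at this position, since the earlier step, a 1.9-fold lower number from compound 1 to compound 2 (0.27 log units; within the scatter), replaced fluoro with trifluoromethyl at a different place in the molecule. Trifluoromethyl has now entered compound 1 at two separate places, and in neither case can the new compound be told apart from compound 1 in this assay, though a single step at each place is thin support for any broader rule. No supporting measurement is available that could explain the size of this step.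

At this position the compounds shown carry only methyl and trifluoromethyl, so they do not reveal whether the number can move beyond the scatter there at all. A group of a different kind in that spot, such as an amine, a carboxylic acid or a longer chain, remains an open question in this assay.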